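Aryl variation on the ring amine nitrogen: compound 4

The compounds below may be only part of what the source reports. "The series", "measured", "known", "first", "only" and "open" are said of these compounds alone.

Measured so far in an assay on HEK293 cells for inhibition of Voltage-dependent T-type calcium channel subunit alpha-1G (Homo sapiens), read by patch clamp; on this read-out higher numbers stand for weaker inhibition and lower numbers for stronger inhibition:
compound 1 `O=C(CCCN1CCN(c2ccccc2F)CC1)Nc1ccc(Cl)cc1` gives 3630 nM
compound 2 `O=C(CCCN1CCN(c2ccccc2Cl)CC1)Nc1ccc(Cl)cc1` gives 6010 nM
compound 3 `O=C(CCCN1CCN(c2ccc(Cl)cc2)CC1)Nc1ccc(Cl)cc1` gives 2640 nM

Compound 3 carries the lowest number of the three; its nearest neighbour is separated by a 1.4-fold lower number from compound 1 to compound 3 (0.14 log units; within the scatter), within the scatter, and its furthest by a 2.3-fold lower number from compound 2 to compound 3 (0.36 log units; beyond the scatter), beyond it. Compound 4 `COc1cccc(N2CCN(CCCC(=O)Nc3ccc(Cl)cc3)CC2)c1` differs from compound 3 by 3-methoxyphenyl in place of 4-chlorophenyl on an amine nitrogen in a ring. Within the data shown here, the steps that bear on this change are the earlier swaps of the aryl group at the same place, a 1.4-fold lower number from compound 1 to compound 3 (0.14 log units; within the scatter) and a 2.3-fold lower number from compound 2 to compound 3 (0.36 log units; beyond the scatter), both small. A similarly small step is therefore expected for compound 4 in this assay, probably none beyond the scatter, with a slight lean toward a higher number given that compound 3 already stands at 2640 nM, the lowest of the set. The estimate for compound 4 is 3500 nM (range 1500 nM to 8000 nM), an expected 1.3-fold higher number from compound 3 to compound 4 (0.12 log units; within the scatter).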

Compound 4, half-maximal inhibitory concentration: 2780 nM
Beside the measured number, compound 4's estimate is 1.3-fold (0.10 log units) above it; measured number inside the range.
By their numbers in this assay, from the lowest: compounds 3, 4, 1 and 2 (each within the scatter of the next, the first and the last beyond it).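

In this assay, among these compounds, the first aryl group without a halogen, 3-methoxyphenyl, which brings a hydrogen-bond acceptor, gives a number level with 4-chlorophenyl (a 1.1-fold higher number from compound 3 to compound 4 (0.02 log units; within the scatter)) and with 2-fluorophenyl (a 1.3-fold lower number from compound 1 to compound 4 (0.12 log units; within the scatter)). Among the compounds shown here, only 2-chlorophenyl stands apart from it (a 2.2-fold lower number from compound 2 to compound 4 (0.33 log units; beyond the scatter)), so the one step beyond the scatter at this position still involves that group.

Open, as far as these compounds go, is whether 2-methoxyphenyl, 4-methoxyphenyl, or an aryl group bearing an amine or a carboxylic acid would stay level with these. No measurement at hand accounts for these values.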